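The compounds below may be only part of what the source reports. "The series", "measured", "known", "first", "only" and "open" are said of these compounds alone.

Measured compounds, this assay:
compound 1 `CN(C)CCCCCCCCCOc1ccc2oc(-c3ccccc3)cc(=O)c2c1` — 202 nM
compound 2 `CN(C)CCCCCCCCCCOc1ccc2oc(-c3ccccc3)cc(=O)c2c1` — 341 nM
compound 3 `O=c1cc(-c2ccccc2)oc2ccc(OCCCCCCN3CCCC(O)C3)cc12` — 77 nM

In an assay on isolated protein (Cavia porcellus) with Sigma non-opioid intracellular receptor 1 (Homo sapiens) as the target, read by radioligand binding (on this read-out higher numbers stand for weaker inhibition and lower numbers for stronger inhibition), compound 3 gives the lowest number of the three. The step of a 2.6-fold lower number from compound 1 to compound 3 (0.42 log units; beyond the scatter) and the step of a 4.4-fold lower number from compound 2 to compound 3 (0.65 log units; beyond the scatter) both place compound 3 beyond the scatter from the two dimethylamino compounds, whereas a 1.7-fold higher number from compound 1 to compound 2 (0.23 log units; within the scatter) stays within it.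

Compound 4 `CCN(CC)CCCCCCOc1ccc2oc(-c3ccccc3)cc(=O)c2c1` is not yet measured. Its difference from compound 3 is diethylamino in place of 3-hydroxypiperidin-1-yl on a saturated chain carbon, six bonds along the chain from an oxygen on an aromatic ring. For the measured compounds named here, no measured step covers exactly this exchange at the same chain length. The nearest guides are the two steps into compound 3: both replaced an open-chain dimethylamino terminus by the 3-hydroxypiperidin-1-yl ring and lowered the number modestly. Compound 4 goes back to an open-chain amine, diethylamino, so the expectation is a modest rise in the number, roughly reversing those steps, though the chain-length change that accompanied them leaves the size uncertain.

Compound 4 is therefore estimated at 170 nM in this assay, with a range of 70 nM to 420 nM. The expected step is a 2.2-fold higher number from compound 3 to compound 4 (0.34 log units; beyond the scatter).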

Compound 4, half-maximal inhibitory concentration: 100 nM
Beside the measured number, compound 4's estimate is 1.7-fold (0.23 log units) above it, and the stated range covers the measured number.
By their numbers in this assay, from the lowest: compounds 3 and 4 (each within the scatter of the next); then compounds 1 and 2 (each within the scatter of the next).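

In this assay the exchange of the ring for an open-chain amine gives a 1.3-fold higher number from compound 3 to compound 4 (0.11 log units; within the scatter), so at six bonds along the chain from the oxygen on the aromatic ring, diethylamino and 3-hydroxypiperidin-1-yl cannot be told apart, and the ring with its hydroxyl is not needed for a number in this range. The steps of a 3.4-fold lower number from compound 2 to compound 4 (0.53 log units; beyond the scatter) and a 2.0-fold lower number from compound 1 to compound 4 (0.31 log units; beyond the scatter) are both beyond the scatter, so a second terminal amine on the six-bond chain also sits apart from the two longer-chain dimethylamino compounds, although these steps change chain and amine together. No measured evidence here accounts for these numbers.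

A dimethylamino group six bonds along the chain would separate the effect of chain length from that of the amine. Unsubstituted piperidin-1-yl would test the hydroxyl on its own.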